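The compounds below may be only part of what the source reports. "The series", "measured", "known", "first", "only" and "open" are said of these compounds alone.

Notes on the series. In a functional assay on SW-620 cells (Homo sapiens) for antiproliferative activity, read by sulforhodamine B assay, with a stated time of 48 h (a lower number here means a stronger inhibitor, a higher number a weaker inhibitor), compound 1 `O=C(CCCCCCN1C(=O)/C(=N\O)c2cc(F)ccc21)NO` gives 110 nM and compound 2 `O=C(CCCCCCN1C(=O)/C(=N\O)c2cc(Br)ccc21)NO` gives 290 nM. Among the measured compounds shown here, compound 2 thus holds the higher of the two numbers so far, and the gap between them lies beyond the scatter.

The next compound is compound 3 `Cc1ccc2c(c1)/C(=N/O)C(=O)N2CCCCCCC(=O)NO`, with the change (methyl in place of bromo on an aromatic carbon), that is, methyl in place of bromo on an aromatic carbon. For the measured compounds named here, the only measured step that bears on it is a 2.6-fold higher number from compound 1 to compound 2 (0.42 log units; beyond the scatter), a modest step for bromo in place of fluoro on an aromatic carbon. Going by the values given here, no compound carrying methyl has been measured, so this single step is the only guide. In this assay a modest move to a lower number is expected, smaller than that step. The expected step is a 1.6-fold lower number from compound 2 to compound 3 (0.21 log units; within the scatter). For compound 3 the estimate is 180 nM, with an expected range of 75 nM to 430 nM.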

Compound 3, half-maximal inhibitory concentration: 990 nM
For compound 3 the middle estimate is 5.5-fold (0.74 log units) below the measured one; measured number outside the range, above it.
By their numbers in this assay, from the lowest: compound 1; then compound 2; then compound 3.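

In this assay, the aromatic carbon that carries the substituent now shows a change beyond the two halogens: methyl in place of bromo gives a 3.4-fold higher number from compound 2 to compound 3 (0.53 log units; beyond the scatter), and methyl in place of fluoro gives a 9.0-fold higher number from compound 1 to compound 3 (0.95 log units; beyond the scatter), both beyond the scatter. With three compounds, the numbers rise from fluoro through bromo to methyl, and compound 3 has the highest number. Bromo and methyl each count one heavy atom and no hydrogen-bond donors or acceptors, yet the swap is not neutral at this carbon.

From the compounds shown here alone, it remains open whether chloro would fall among the two halogens measured here, and whether methoxy or an amine would stay nearer the halogens or nearer methyl. Ethyl would test whether a longer chain at this carbon moves the number further from that of compound 3, and no available measurement explains the differences seen in this set.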